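The compounds below may be only part of what the source reports. "The series", "measured", "known", "first", "only" and "open" are said of these compounds alone.

Values in an ADME assay on cells (Peritoneal macrophage, Mus musculus, strain Balb/c) for cytotoxicity, read by resazurin assay, with a stated time of 72 h; a lower number here means that less compound is tolerated, a higher number that more compound is tolerated
compound 1 `CC1(Cc2cccc(/C(N)=N/O)c2)CC(S(=O)(=O)c2ccc(F)cc2)=C(c2ccc(/C(N)=N/O)cc2)O1` gives 50200 nM
compound 2 `CC1(Cc2cccc(C(F)(F)F)c2)CC(S(=O)(=O)c2ccc(F)cc2)=C(c2ccc(/C(N)=N/O)cc2)O1` gives 49800 nM
compound 3 `CC1(Cc2cccc([N+](=O)[O-])c2)CC(S(=O)(=O)c2ccc(F)cc2)=C(c2ccc(/C(N)=N/O)cc2)O1` gives 86600 nM

Compound 3 lies within the usual scatter of compound 1 and compound 2, and no order among the three can be read. Among the measured compounds shown here, compound 4 `Cc1ccc(CC2(C)CC(S(=O)(=O)c3ccc(F)cc3)=C(c3ccc(/C(N)=N/O)cc3)O2)cc1` carries 4-methylphenyl in place of 3-nitrophenyl on a saturated chain carbon bound to a saturated ring carbon as its only change. For the measured compounds named here, no measured compound holds this new group. The nearest guide is what other swaps on that aromatic ring did: a 1.0-fold lower number from compound 1 to compound 2 (0.00 log units; within the scatter) and a 1.7-fold higher number from compound 1 to compound 3 (0.24 log units; within the scatter) and a 1.7-fold higher number from compound 2 to compound 3 (0.24 log units; within the scatter) all stayed within the scatter. No step beyond the scatter is therefore expected in this assay for this swap. The estimated step is a 1.4-fold lower number from compound 3 to compound 4 (0.16 log units; within the scatter) and it remains within the scatter. Compound 4 is expected at 60000 nM with a range from 30000 nM to 110000 nM in this estimate.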

Compound 4, half-maximal cytotoxic concentration: 54400 nM
Compound 4: the middle estimate sits 1.1-fold (0.04 log units) above what was measured; the range from low to high includes it.
By their numbers in this assay, from the lowest: compounds 2, 1, 4 and 3 (each within the scatter of the next).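

In this assay the carbon-only 4-methylphenyl group, with no hydrogen-bond acceptors, gives a 1.6-fold lower number from compound 3 to compound 4 (0.20 log units; within the scatter) and a 1.1-fold higher number from compound 2 to compound 4 (0.04 log units; within the scatter) and a 1.1-fold higher number from compound 1 to compound 4 (0.03 log units; within the scatter). So this place on a saturated chain carbon bound to a saturated ring carbon now holds a group of carbon only as well as the earlier groups, with every step inside the scatter and no order among the four compounds. Nothing measured here offers an explanation for this.

Still open, as far as these compounds go, is whether an amine or a carboxylic acid on this aromatic ring would give a step beyond the scatter. A longer chain in place of the benzyl group is equally untested among the compounds shown.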